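Replacing Phenyl With 4-Methoxy-3,5-dimethylphenyl on a Cyclopentenone

The compounds below may be only part of what the source reports. "The series", "measured", "known", "first", "only" and "open" are said of these compounds alone.

Measured so far:
Compound 1, `COc1ccc(C2=C(c3cc(OC)c(OC)c(OC)c3)C(=O)CC2O[SiH2]C(C)(C)C)cc1OC`, gives > 100 ug/mL in an ADME assay on HEK293 cells (Homo sapiens) for cytotoxicity, read by MTT assay, with a stated time of 72 h (on this read-out higher numbers stand for weaker inhibition and lower numbers for stronger inhibition), a limit of the assay rather than a number.
Compound 2, `COc1cc(C2=C(c3ccccc3)C(O[SiH2]C(C)(C)C)CC2=O)cc(OC)c1OC`, gives > 100 ug/mL in this assay, again a limit rather than a number.

Within the data shown here, compound 2 therefore stands at the upper edge of what this assay can report, and so does compound 1: the only evidence available is the limit of > 100 ug/mL in this assay, at which 2 of the 2 values shown sit, so no ordering of the two can be read from these values. The step that the two limits leave unreadable from compound 1 to compound 2 is accordingly unreadable in size. Compound 3, `COc1cc(C2=C(c3cc(C)c(OC)c(C)c3)C(O[SiH2]C(C)(C)C)CC2=O)cc(OC)c1OC`, has not yet been measured in this assay. It differs from compound 2 by 4-methoxy-3,5-dimethylphenyl in place of phenyl on a double-bonded ring carbon. Among the measured compounds shown here, the one measured step that bears on a change at this same position is the step from compound 1 to compound 2, and its size is hidden by the two limits, so no step beyond the scatter can be predicted in either direction. Compound 3 is therefore expected to sit near the same limit, with the step of a number no higher from compound 2 to compound 3 (the limit leaves the size open) estimated as essentially flat. The estimate for compound 3 is 100 ug/mL, with a likely range from 50 ug/mL to 200 ug/mL.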

Compound 3, half-maximal inhibitory concentration: 29 ug/mL
Beside the measured number, compound 3's estimate is 3.4-fold (0.54 log units) above it; measured number below the stated range.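

Compound 3 is the first of these compounds to give a real number rather than a limit, which shows that the group on this double-bonded ring carbon can change the read-out in this assay. With 4-methoxy-3,5-dimethylphenyl at this carbon, the change from phenyl gives an at least 3.4-fold lower number from compound 2 to compound 3 (0.53 log units; beyond the scatter), and the change from 3,4-dimethoxyphenyl gives an at least 3.4-fold lower number from compound 1 to compound 3 (0.53 log units; beyond the scatter). The full size of these two steps stays unknown, and the step between the two earlier compounds cannot be read, because those compounds give only a limit: the limit of > 100 ug/mL in this assay, at which 2 of the 3 values shown sit.

The compounds shown do not tell whether the methoxy group or the methyl groups of 4-methoxy-3,5-dimethylphenyl account for the lower number in compound 3, since these groups enter together. They also leave open how this assay would read with an amine or a carboxylic acid on the aromatic ring at this carbon, so the result marks one active change and not yet a trend.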